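This account rests on a few compounds, and the source may have more. Where it says the series, first, only, none or still open, it means among the compounds named here.

In a functional assay on HeLa cells (Homo sapiens) for inhibition, read by sulforhodamine B assay (a lower number here means a stronger inhibitor, a higher number a weaker inhibitor), compound 1 `CCCc1ccc(NC2=CC(=O)c3c(nc4n3[C@H]3OC[C@@H](O)[C@H]3OC4)C2=O)cc1` gives 6030 nM, the highest of the two numbers in hand. Compound 3 `COc1ccc(NC2=CC(=O)c3nc4n(c3C2=O)[C@H]2OC[C@@H](O)[C@H]2OC4)cc1` gives 4780 nM, within the scatter of compound 1. Compound 2 `O=C1C=C(NCc2ccccc2)C(=O)c2c1nc1n2[C@H]2OC[C@@H](O)[C@H]2OC1` reaches only the limit > 8000 nM in this assay. For the measured compounds named here, the single measured step, an at least 1.6-fold lower number from compound 2 to compound 3 (0.22 log units; that floor lies within the scatter), exchanges benzyl for 4-methoxyphenyl on the amine nitrogen and concerns neither propyl nor iodo, so it does not bear on the change now in question. Compound 4 `O=C1C(Nc2ccc(I)cc2)=CC(=O)c2c1nc1n2[C@H]2OC[C@@H](O)[C@H]2OC1` differs from compound 1 by iodo in place of propyl on an aromatic carbon. Compound 1 gives 6030 nM with propyl in that place and compound 3 gives 4780 nM with methoxy there, within the scatter of each other, so the step of a 1.2-fold lower number from compound 1 to compound 4 (0.08 log units; within the scatter) is expected to stay within the scatter. Compound 4 is therefore estimated at 5000 nM, between 2000 nM and 12000 nM.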

Compound 4, half-maximal inhibitory concentration: 4010 nM
Estimate against measurement, compound 4: 1.2-fold (0.10 log units) above, within the range that was stated.
By their numbers in this assay, from the lowest: compounds 4, 3 and 1 (each within the scatter of the next). At a limit, above all of these: compound 2.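

In this assay, iodo in place of propyl on this aromatic carbon gives a 1.5-fold lower number from compound 1 to compound 4 (0.18 log units; within the scatter), a direct reading at this place. Compound 3, with methoxy there, gives 4780 nM, so propyl, iodo and methoxy all stand within the scatter of one another at this place. Nothing at hand gives a cause for this result. The compounds shown leave open whether any group on this carbon moves the number beyond the scatter. An amine, a carboxylic acid or a longer chain there remains untested in what is shown.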